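Cell Toxicity of Compound 4 Estimated from Compound 3

This account rests on a few compounds, and the source may have more. Where it says the series, first, only, none or still open, it means among the compounds named here.

The compounds share a core in which a tetrazole-bearing phenyl ring carries a dimethylpyrrole; the simplest is compound 1 `Cc1ccc(C)n1-c1cccc(-c2nnn[nH]2)c1`. In an ADME assay on MT2 cells (Homo sapiens) for cytotoxicity, read by XTT assay, with a stated time of 4 days (on this read-out lower numbers stand for higher toxicity in this test and higher numbers for lower toxicity in this test), compound 1 gives 250000 nM. Compound 2 `Cc1cc(C=C(C#N)C#N)c(C)n1-c1cccc(-c2nnn[nH]2)c1` adds a 2,2-dicyanoethenyl group on an aromatic carbon. For compound 2 the assay reports only a limit, > 400000 nM, not a number, so the step of an at least 1.6-fold higher number from compound 1 to compound 2 (0.20 log units; that floor lies within the scatter) is only a floor. Compound 3 `Cc1cc(/C=C2\SC(=S)N(c3cccc(O)c3)C2=O)c(C)n1-c1cccc(-c2nnn[nH]2)c1` carries a larger side chain and gives 35600 nM in this assay; of the two plain numbers it is the lower, and compound 1 is the nearer, higher one. Compound 4 `Cc1cc(/C=C2\SC(=S)N(c3ccc(C(F)(F)F)cc3)C2=O)c(C)n1-c1cccc(-c2nnn[nH]2)c1` is not yet measured. It differs from compound 3 in one place: 4-(trifluoromethyl)phenyl in place of 3-hydroxyphenyl on an amide-type nitrogen in a ring. Among the compounds with values here, no measured step touches this position; the single measured step concerns a different site and lies within the usual scatter, so it offers no guide to the direction here. In the absence of any comparable step, compound 4 is expected to stay close to compound 3, with the estimated step of a 1.8-fold lower number from compound 3 to compound 4 (0.25 log units; within the scatter) small. Compound 4 is therefore estimated at 20000 nM in this assay, within a range from 6000 nM to 70000 nM.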

Compound 4, half-maximal cytotoxic concentration: 27100 nM
Beside the measured number, compound 4's estimate is 1.4-fold (0.13 log units) below it; the range from low to high includes it.
By their numbers in this assay, from the lowest: compounds 4 and 3 (each within the scatter of the next); then compound 1. At a limit, above all of these: compound 2.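

At this position, the amide-type nitrogen of the five-membered non-aromatic ring with 1 nitrogen and 1 sulfur, putting 4-(trifluoromethyl)phenyl in place of 3-hydroxyphenyl gives a 1.3-fold lower number from compound 3 to compound 4 (0.12 log units; within the scatter) in this assay, so on this read-out the two compounds cannot be told apart. Within the data shown here, this is the first direct look at the position, and it shows that a sizeable exchange can leave the toxicity number within ordinary repeat variation: the group that leaves has 1 hydrogen-bond donor and 1 hydrogen-bond acceptor, while the group that enters has 0 of each and more heavy atoms. Nothing measured here says why the number stays within the scatter after this exchange.

Two phenyl groups, differing both in their substituent and in where it sits, cannot separate those two features, so 4-hydroxyphenyl or 3-(trifluoromethyl)phenyl on the same nitrogen would be needed to tell them apart. From the compounds shown here alone, it also remains open whether this tolerance extends to quite different groups at this nitrogen, such as a phenyl ring bearing an amine or a carboxylic acid, or a plain alkyl chain in place of the ring.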